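Aryl exchange on the shared core: compound 2 to compound 4

A few compounds are considered here, and "the series" means these few. Any claim that something is new, unique, unknown or untested is made for them only; others in the source may bear on it.

In a functional assay on SGC-7901 cells (Homo sapiens) for cytotoxicity, read by MTT assay, with a stated time of 48 h (on this read-out higher numbers stand for weaker inhibition and lower numbers for stronger inhibition), compound 1 (`Cc1ccccc1-c1nnc(SCCn2c([N+](=O)[O-])cnc2C)o1`) gives 32300 nM and compound 2 (`Cc1ncc([N+](=O)[O-])n1CCSc1nnc(-c2ccc(N)cc2)o1`) gives 31700 nM as its value. Compound 3 (`CCOc1ccc(-c2nnc(SCCn3c([N+](=O)[O-])cnc3C)o2)cc1`) gives 14100 nM as its value. Compound 2 therefore stands level with compound 1 and higher than compound 3. Compound 4 (`Cc1ncc([N+](=O)[O-])n1CCSc1nnc(-c2ccccc2O)o1`) carries 2-hydroxyphenyl in place of 4-aminophenyl on an aromatic carbon. Going by the values given here, two measured steps bear on this: exchanging 2-methylphenyl for 4-aminophenyl changed nothing beyond the scatter (a 1.0-fold lower number from compound 1 to compound 2 (0.01 log units; within the scatter)), while ethoxy in place of amino was modest (a 2.2-fold lower number from compound 2 to compound 3 (0.35 log units; beyond the scatter)). No step beyond the scatter is therefore expected in this assay (a 1.2-fold lower number from compound 2 to compound 4 (0.09 log units; within the scatter)). For compound 4 the estimated value is 26000 nM (expected range 11000 nM to 55000 nM).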

Compound 4, half-maximal inhibitory concentration: 30500 nM
Compound 4: middle estimate off by 1.2-fold (0.07 log units), on the low side; the measured number falls inside the stated range.
By their numbers in this assay, from the lowest: compound 3; then compounds 4, 2 and 1 (each within the scatter of the next).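

At this aromatic carbon, this assay now has a third aryl group that reads level with the other two: a 1.0-fold lower number from compound 2 to compound 4 (0.02 log units; within the scatter), and a 1.1-fold lower number from compound 1 to compound 4 (0.02 log units; within the scatter). Going from 4-aminophenyl to 2-hydroxyphenyl alters both the group and its place on the phenyl ring, yet the number stays within the scatter. No measurement at hand accounts for this flat result. Open, on these data alone, is whether 4-hydroxyphenyl would read like 2-hydroxyphenyl, and whether a carboxylic acid on the phenyl ring would move the number.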